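From Compound 2 to Compound 4: a Ring Swap

This account rests on a few compounds, and the source may have more. Where it says the series, first, only, none or still open, it means among the compounds named here.

Of the compounds shown here, three have been tested in a functional assay on the whole organism (plasma, strain Sprague-Dawley) with Rattus norvegicus as the target, with a stated time of 2 h, at a dose of 50 mg/kg by the oral route; on this read-out higher numbers stand for a stronger effect at the one dose given and lower numbers for a weaker effect. Compound 1 `c1ccc(C(/N=C2\CCCCCN2)C2CC2)cc1` gives 41%, compound 3 `Cc1ccc(C(/N=C2\CCCCCN2)C2CC2)c(C)c1` gives 43%, and compound 2 `c1ccc(C(/N=C2\CCCCCCN2)C2CC2)cc1` gives 46%, the highest of the three numbers, though its gaps to compound 3 and to compound 1 both fall within the scatter, so no order among them can be claimed. Compound 4 `c1ccc(C(/N=C2\CCCCCCN2)c2ccco2)cc1` has not yet been measured in this assay; it differs from compound 2 in one place: furan-2-yl in place of cyclopropyl on a saturated chain carbon bound to an aromatic carbon and a double-bonded nitrogen. No measured pair shows this change, so nothing shown tells its effect. Compound 4 is expected to give a number near that of compound 2, with an expected step of a number 2 percentage points lower from compound 2 to compound 4 (within the scatter) that stays within the scatter. The estimate for compound 4 is 44%, ranging from 25% to 63%.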

Compound 4, a percentage reported as inhibition, in the whole organism at one dose (the size of the read-out at that dose, not a potency): 42%
Estimate against measurement, compound 4: 2 percentage points above; the range from low to high includes it.
By their numbers in this assay, from the lowest: compounds 1, 4, 3 and 2 (each within the scatter of the next).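

For the compounds shown here, this is the first step read at this position, the saturated chain carbon bound to an aromatic carbon and a double-bonded nitrogen: in this assay, furan-2-yl in place of cyclopropyl gives a number 4 percentage points lower from compound 2 to compound 4 (within the scatter). A five-membered aromatic ring with 1 hetero atom can therefore stand here in place of a three-membered carbon ring without a shift that rises above the scatter at this one dose. No measurement shown speaks to why the two groups read alike.

As far as these compounds go, what an amine or a carboxylic acid at this place would give stays open. So does whether other doses would separate compound 2 and compound 4.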